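Ring swap at the biaryl position of a Substance-P ligand

The compounds below may be only part of what the source reports. "The series", "measured", "known", "first", "only" and "open" are said of these compounds alone.

Compounds measured so far:
Compound 1 `Cn1c(-c2ccc(Cl)cc2)c(CCC(=O)N2CCC(O)(Cc3ccccc3)CC2)c2cc(-c3ccccn3)ccc21`: 1.7 nM
Compound 2 `Cn1c(-c2ccc(Cl)cc2)c(CCC(=O)N2CCC(O)(Cc3ccccc3)CC2)c2cc(-c3ccncc3)ccc21`: 5.5 nM

In an assay on CHO cells for displacement of a labelled ligand from Substance-P receptor (Homo sapiens) (a higher number here means a weaker inhibitor, a lower number a stronger inhibitor), compound 1 gives 1.7 nM. Compound 2 shares the same core, and in this assay compound 2 gives 5.5 nM, the highest of the two numbers; its nearest neighbour is compound 1, and the step of a 3.2-fold higher number from compound 1 to compound 2 (0.51 log units; beyond the scatter) is the only one available. Compound 3 `Cn1c(-c2ccc(Cl)cc2)c(CCC(=O)N2CCC(O)(Cc3ccccc3)CC2)c2cc(-n3cccc3)ccc21` is not yet measured; it differs from compound 2 by 1H-pyrrol-1-yl in place of pyridin-4-yl on an aromatic carbon. Among the compounds with values here, the only step bearing on this change is the earlier heteroaryl exchange, a 3.2-fold higher number from compound 1 to compound 2 (0.51 log units; beyond the scatter), which was modest but beyond the scatter. On that basis the step of a 1.3-fold higher number from compound 2 to compound 3 (0.10 log units; within the scatter) is expected to be small, perhaps within the scatter or slightly toward a higher number. Compound 3 is estimated at 7 nM in this assay, with a range from 2.5 nM to 25 nM.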

Compound 3, half-maximal inhibitory concentration: 2.3 nM
Compound 3: the middle estimate sits 3.0-fold (0.48 log units) above what was measured; the measured number lies below the stated range.
By their numbers in this assay, from the lowest: compounds 1 and 3 (each within the scatter of the next); then compound 2.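

In this assay, putting 1H-pyrrol-1-yl in place of pyridin-4-yl gives a 2.4-fold lower number from compound 2 to compound 3 (0.38 log units; beyond the scatter), so this position accepts a five-membered aromatic ring as well as a six-membered one. Against pyridin-2-yl, the same ring gives a 1.4-fold higher number from compound 1 to compound 3 (0.13 log units; within the scatter), which leaves compound 1 and compound 3 indistinguishable in this measurement. The weaker number of compound 2 is therefore not shared by every ring exchange here, and among these three compounds only pyridin-4-yl stands apart.

Going by these compounds, whether the position also accepts a group that is not an aromatic ring, such as a morpholine ring, a carboxylic acid or a longer chain, remains open. Nothing available explains why pyridin-4-yl differs from the other two rings.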